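A few compounds are considered here, and "the series" means these few. Any claim that something is new, unique, unknown or untested is made for them only; others in the source may bear on it.

Series notes. For the measured compounds named here, the shared core of compound 1 `O=C(Nc1cccc(F)c1)N[C@H]1CC[C@H](Oc2ccc(F)cc2)CC1` carries a urea-type linkage to a substituted phenyl ring; in a functional assay on CRL2813 cells (Homo sapiens) for cytotoxicity, read by sulforhodamine B assay, with a stated time of 5 days (on this read-out higher numbers stand for weaker inhibition and lower numbers for stronger inhibition), compound 1 gives 8300 nM, the highest of the three numbers known here. Compound 2 `O=C(Nc1ccccc1Br)N[C@H]1CC[C@H](Oc2ccc(F)cc2)CC1` gives 7700 nM, and the change in a 1.1-fold lower number from compound 1 to compound 2 (0.03 log units; within the scatter) introduces 2-bromophenyl in place of 3-fluorophenyl on an amide-type nitrogen. Compound 3 `O=C(Nc1cccc(C(F)(F)F)c1)N[C@H]1CCCC[C@@H]1Oc1ccc(C(F)(F)F)cc1` is built on a different core and differs from compound 1 in several places; in this assay compound 3 gives 3100 nM. Going by the values given here, no single step links compound 3 to compound 1, so the two values only show a gap beyond the scatter.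

Compound 4 `O=C(Nc1cccc(I)c1)N[C@H]1CC[C@H](Oc2ccc(F)cc2)CC1` is not yet measured. It differs from compound 1 by iodo in place of fluoro on an aromatic carbon. Among the compounds with values here, the only step that bears on this is the halogen exchange on the same phenyl ring in compound 2, which stayed within the scatter. Compound 4 is therefore expected to sit close to compound 1, with the step of a 1.4-fold lower number from compound 1 to compound 4 (0.14 log units; within the scatter) expected to stay within the scatter or only slightly beyond it. The estimate for compound 4 is 6000 nM, with a range from 2500 nM to 14000 nM.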

Compound 4, half-maximal inhibitory concentration: 5200 nM
Compound 4: the middle estimate sits 1.2-fold (0.06 log units) above what was measured; low and high end bracket the measured number.
By their numbers in this assay, from the lowest: compounds 3, 4, 2 and 1 (each within the scatter of the next, the first and the last beyond it).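

The exchange of 3-fluorophenyl for 3-iodophenyl gives a 1.6-fold lower number from compound 1 to compound 4 (0.20 log units; within the scatter) in this assay, so at this place on the aromatic ring, fluoro and iodo cannot be told apart despite the change of halogen. The comparison with the other halogenated urea gives a 1.5-fold lower number from compound 2 to compound 4 (0.17 log units; within the scatter), which means that compounds 1, 2 and 4 all lie within the scatter of one another, and across these three compounds the choice of halogen and its place on the ring produce no readable difference. No measurement available here offers an explanation for this flat result.

Going by these compounds, whether a group other than a halogen at this place, such as an amine or a carboxylic acid, would shift the number beyond the scatter remains open. For the compounds shown here, also open is which of its several differences separates compound 3 from compound 1, as no single step connects the two.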